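Amide swap on the side chain of compound 2

The source may report more compounds than this note shows. Statements on the series, on what has been measured and on what is new or still open speak of the compounds shown alone.

Compound 1 `Oc1cc(-c2ccccc2)ccc1C(O)(C(F)(F)F)C(F)(F)F` reaches, in an assay on isolated protein for inhibition of receptor-type tyrosine-protein phosphatase C (Homo sapiens), read by spectrophotometry (a lower number here means a stronger inhibitor, a higher number a weaker inhibitor), only a limit of > 500000 nM. Compound 2 `CCN(CC)C(=O)COc1ccc2cc(C(O)(C(F)(F)F)C(F)(F)F)c(O)cc2c1` likewise gives only a limit, > 20000 nM, in this assay. Compound 2 thus sits at the limit of > 20000 nM in this assay, at which 1 of the 2 values shown sits, and has no measured number of its own. Compound 3 `O=C(COc1ccc2cc(C(O)(C(F)(F)F)C(F)(F)F)c(O)cc2c1)Nc1ccccc1` carries anilino in place of diethylamino on a carbonyl carbon. For the measured compounds named here, no measured step is available for this change, so the step that the limit leaves unreadable from compound 2 to compound 3 in this assay is expected to stay within the usual scatter. Compound 3 is expected to give 30000 nM in this assay, within 5000 nM to 200000 nM, most likely again reported only as a limit.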

Compound 3, half-maximal inhibitory concentration: > 20000 nM
Compound 3: no number, only a limit; the forecaster's own chance of this, stated with the estimate: 70%; the middle value does not contradict the limit.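

Compound 2 and compound 3 both give only limits, and no step can be read between them. The compounds shown leave open how far either amide side chain sits from a measurable inhibitory concentration.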